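Cyclohexyl for phenyl on an inactive anilino series

The source may hold more compounds than are shown below. What is called first, only, known or untested is meant among the compounds shown, and "the series" means these compounds.

Measured so far:
compound 1, `O=C1C(Nc2ccccc2)=CC(=O)c2c1nc1n2[C@H]2OC[C@@H](O)[C@H]2OC1`, in a functional assay on MCF7 cells (Homo sapiens) for inhibition, read by sulforhodamine B assay (on this read-out higher numbers stand for weaker inhibition and lower numbers for stronger inhibition), compound 1 gives only a limit, > 4000 nM.
compound 2, `O=C1C=C(NC2CCCC2)C(=O)c2c1nc1n2[C@H]2OC[C@@H](O)[C@H]2OC1`, in this assay compound 2 gives only a limit, > 16000 nM.

Compound 1 stands at a limit rather than a number, (the limit of > 4000 nM in this assay, at which 1 of the 2 values shown sits). Compound 2 likewise stands at a limit, (the limit of > 16000 nM in this assay, at which 1 of the 2 values shown sits). Compound 3, `O=C1C(NC2CCCCC2)=CC(=O)c2c1nc1n2[C@H]2OC[C@@H](O)[C@H]2OC1`, differs from compound 1 by cyclohexyl in place of phenyl on an amine nitrogen. Because compound 1 sits at the limit (the limit of > 4000 nM in this assay, at which 1 of the 2 values shown sits), the step that the limit leaves unreadable from compound 1 to compound 3 is expected to be none beyond the scatter. Compound 3 is therefore estimated at 20000 nM, within 5000 nM to 80000 nM, most probably reported again only as a limit.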

Compound 3, half-maximal inhibitory concentration: > 16000 nM
Compound 3: no number, only a limit; the forecaster's own chance of this, stated with the estimate: 85%; the middle value is on the limit's open side.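

Among these compounds, compound 1 and compound 3 both give only limits, not numbers, so no step between them can be read. Going by these compounds, whether cyclohexyl in place of phenyl changes inhibition, and in which direction, stays open.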